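Trifluoromethoxy for trifluoromethyl on the pendant aryl

The source may hold more compounds than are shown below. What is called first, only, known or untested is meant among the compounds shown, and "the series" means these compounds.

Compound 1 `COc1nc(C(C)(C)C)ccc1[C@@H](c1ccccc1)[C@@](O)(CCN(C)C)c1cccc2ccccc12` carries tert-butyl on an aromatic carbon of the shared core; in a toxicity assay on HeLa cells (Homo sapiens) for cytotoxicity (on this read-out lower numbers stand for higher toxicity in this test and higher numbers for lower toxicity in this test), compound 1 gives > 64 ug/mL, which is a limit of the assay and not a number. Compound 2 `COc1nc(-c2ccc(C(F)(F)F)cc2)ccc1[C@@H](c1ccccc1)[C@@](O)(CCN(C)C)c1cccc2ccccc12` carries 4-(trifluoromethyl)phenyl at that place. In this assay compound 2 gives > 64 ug/mL, again a limit rather than a number. Among the compounds with values here, the one step measured so far, a step that the two limits leave unreadable from compound 1 to compound 2, is thus of unreadable size. (the limit of > 64 ug/mL in this assay, at which 2 of the 2 values shown sit), so compound 2 stands at the ceiling of what this assay reports, with no number to set it against.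

Compound 3 `COc1nc(-c2ccc(OC(F)(F)F)cc2)ccc1[C@@H](c1ccccc1)[C@@](O)(CCN(C)C)c1cccc2ccccc12` differs from compound 2 by trifluoromethoxy in place of trifluoromethyl on an aromatic carbon. Within the data shown here, no measured step bears directly on this change, and the unreadable step between the two measured compounds cannot set a size for it. The expectation for compound 3 therefore rests on the limit of > 64 ug/mL in this assay, at which 2 of the 2 values shown sit: with both values at the limit, the step that the limit leaves unreadable from compound 2 to compound 3 is expected to stay within the scatter, in no readable direction. Compound 3 is estimated at 80 ug/mL in this assay, with a range from 40 ug/mL to 200 ug/mL, and most likely reported once more only as a limit.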

Compound 3, half-maximal cytotoxic concentration: > 64 ug/mL
Compound 3 was reported as a limit; the forecaster's own chance of this, stated with the estimate: 85%; the middle value lies beyond the limit too.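

In this assay compound 3 gives > 64 ug/mL, which is a limit of the assay and not a number. Within the data shown here, no step among compound 1, compound 2 and compound 3 can be read: the limit of > 64 ug/mL in this assay, at which 3 of the 3 values shown sit. The compounds shown leave open whether any group at this place on the shared core gives a numerical reading in this assay.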